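A side-chain swap at the limit of the assay

A few compounds are considered here, and "the series" means these few. Any claim that something is new, unique, unknown or untested is made for them only; others in the source may bear on it.

compound 1 `C/C=C/n1cc(/C=C/C(=O)CC(=O)C(=O)OCC)c2ccccc21`: "not determined" (no result reported)
compound 2 `CCOC(=O)C(=O)CC(=O)/C=C/c1cn(-c2ccc(Cl)cc2)c2ccccc12`: "not determined" (no result reported)
compound 3 `O=C(/C=C/c1cn(-c2ccc(Cl)cc2)c2ccccc12)CC(=O)C(=O)O`: > 40000 nM

These compounds were tested in an ADME assay on HeLa cells (Homo sapiens) for inhibition, read by MTT assay, with a stated time of 48 h; on this read-out higher numbers stand for weaker inhibition and lower numbers for stronger inhibition. Compounds 1 and 2 have no result, so they offer no comparison. In this assay compound 3 gives > 40000 nM, which is a limit of the assay and not a number.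

Compound 4 `CN(C)C(=O)Cn1cc(/C=C/C(=O)CC(=O)C(=O)O)c2ccccc21` keeps the rest of the structure of compound 3 but carries (dimethylcarbamoyl)methyl in place of 4-chlorophenyl on an aromatic nitrogen. Going by the values given here, no measured pair of compounds shows what such a change does here. Among the compounds with values here, compound 3, at > 40000 nM, is the only guide, so no step beyond the usual scatter is expected in this assay, in either direction. The expected change is a step that the limit leaves unreadable from compound 3 to compound 4. The assay may well report only a limit again. For compound 4 the estimated value is 50000 nM, with an expected range of 25000 nM to 100000 nM.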

Compound 4, half-maximal inhibitory concentration: > 40000 nM
Compound 4 gave a limit, no number; the forecaster's own chance of this, stated with the estimate: 80%; the middle value is on the limit's open side.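

Compound 3 and compound 4 both give only a limit in this assay, not a number, so no step between them can be read: the limit of > 40000 nM in this assay, at which 2 of the 4 values shown sit.

The compounds shown leave open whether 4-chlorophenyl or (dimethylcarbamoyl)methyl on the aromatic nitrogen gives a readable inhibition value, and how the two groups would compare.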